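Removing a Fluoro Group Beside an Amidine

The source may hold more compounds than are shown below. What is called first, only, known or untested is meant among the compounds shown, and "the series" means these compounds.

Compound 1, `N=C(N)c1ccc(-c2ccc(-c3ccc(F)cc3)s2)cc1`: 1650 nM
Compound 2, `COc1cc(OC)cc(-c2ccc(-c3ccc(C(=N)N)c(F)c3)s2)c1`: 1440 nM

Both compounds were run in a functional assay on UACC-62 cells (Homo sapiens) for inhibition, read by sulforhodamine B assay, with a stated time of 48 h; on this read-out lower numbers stand for stronger inhibition of growth and higher numbers for weaker inhibition of growth. Compound 1 gives 1650 nM, and compound 2 gives 1440 nM. Within the data shown here, compound 2 shows the lowest of the two numbers, but its only neighbour, compound 1, sits within the usual scatter of it, so the two results cannot be ranked against each other. Among the measured compounds shown here, the compounds also differ in more than one place, so no single structural step connects them.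

Compound 3, `COc1cc(OC)cc(-c2ccc(-c3ccc(C(=N)N)cc3)s2)c1`, has not yet been measured. It differs from compound 2 in one place only: hydrogen in place of fluoro on an aromatic carbon. The change sits on the ring carrying the amidine, ortho to that group and meta to the large thiophene-linked group.

For the measured compounds named here, with no measured step of this kind available, the change of one fluorine for a hydrogen is expected to move the result little, if at all, and a step from compound 2 to compound 3 of about a 1.0-fold higher number from compound 2 to compound 3 (0.02 log units; within the scatter), not beyond the scatter, is estimated. Compound 3 is therefore expected to give roughly 1500 nM in this assay, within a range of 600 nM to 3800 nM.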

Compound 3, concentration for 50% growth inhibition: 1870 nM
Compound 3: middle estimate off by 1.2-fold (0.10 log units), on the low side; low and high end bracket the measured number.
By their numbers in this assay, from the lowest: compounds 2, 1 and 3 (each within the scatter of the next).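

In this assay, hydrogen in place of fluoro on this aromatic carbon, ortho to a group of 3 heavy atoms and meta to a large group, gives a 1.3-fold higher number from compound 2 to compound 3 (0.11 log units; within the scatter). That step lies within the scatter, so compound 2 and compound 3 cannot be ranked against each other, and in this pair the fluoro group shows no readable effect on the result. This is the first reading of the position on its own, since the earlier pair differed in more than one place, but no measurement shown here bears on the reason for this outcome.

The compounds shown leave open whether a chlorine atom, a nitrile or an amine on this same carbon would also stay within the scatter, as only fluoro and hydrogen appear there. They also leave open whether the same swap would read alike with the fluoro-bearing ring of compound 1 at the far end of the molecule, in place of the ring with two methoxy groups found in compound 2 and compound 3.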